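Ring substituent change on the shared core, compound 4 outlook

A few compounds are considered here, and "the series" means these few. Any claim that something is new, unique, unknown or untested is made for them only; others in the source may bear on it.

The series keeps one core and varies the group on an aromatic carbon of the five-membered ring. Compound 1 `CCc1nnn(Cc2ccc(C(F)(F)F)cc2)c1C(=O)N[C@@H](C)c1ccc(C(=O)O)cc1` carries ethyl there; in a functional assay on CHO cells for antagonist activity at prostaglandin E2 receptor EP4 subtype (Homo sapiens), read by calcium flux, with a stated time of 15 min (a lower number here means a stronger inhibitor, a higher number a weaker inhibitor), compound 1 reaches only the limit > 10000 nM, a limit rather than a number. Compound 2 `C[C@H](NC(=O)c1c(C2CCC2)nnn1Cc1ccc(C(F)(F)F)cc1)c1ccc(C(=O)O)cc1` carries cyclobutyl, and in this assay compound 2 gives 75.3 nM. Compound 3 `C[C@H](NC(=O)c1c(C2CCCCC2)nnn1Cc1ccc(C(F)(F)F)cc1)c1ccc(C(=O)O)cc1` carries cyclohexyl; in this assay compound 3 gives 161 nM. Of the two numbers seen, compound 3 has the higher one: a 2.1-fold higher number from compound 2 to compound 3 (0.33 log units; beyond the scatter). Both ring groups sit far from the ethyl case, since an at least 130-fold lower number from compound 1 to compound 2 (2.12 log units; beyond the scatter) and an at least 62-fold lower number from compound 1 to compound 3 (1.79 log units; beyond the scatter), the latter set against (the limit of > 10000 nM in this assay, at which 1 of the 3 values shown sits).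

Compound 4 `C[C@H](NC(=O)c1c(-c2ccc(F)cc2)nnn1Cc1ccc(C(F)(F)F)cc1)c1ccc(C(=O)O)cc1` differs from compound 3 by 4-fluorophenyl in place of cyclohexyl on an aromatic carbon. Among the compounds with values here, no measured step exchanges a saturated ring for an aromatic one at this carbon. The steps that do bear on the position show a large gain from ethyl to either cycloalkyl and only a modest difference between the two cycloalkyls. A six-membered ring of a different kind is therefore expected to stay near compound 3 or move somewhat lower, with wide uncertainty: a 1.6-fold lower number from compound 3 to compound 4 (0.21 log units; within the scatter). Compound 4 is estimated at 100 nM, with a range from 25 nM to 400 nM.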

Compound 4, half-maximal inhibitory concentration: 57.9 nM
For compound 4 the middle estimate is 1.7-fold (0.24 log units) above the measured one; the measured number falls inside the stated range.
By their numbers in this assay, from the lowest: compounds 4 and 2 (each within the scatter of the next); then compound 3. At a limit, above all of these: compound 1.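

An aromatic ring holds up at this carbon of the shared core, and in this assay 4-fluorophenyl improves on cyclohexyl, with a 2.8-fold lower number from compound 3 to compound 4 (0.44 log units; beyond the scatter), even though it brings the larger count of heavy atoms. Against cyclobutyl there is no separation, with a 1.3-fold lower number from compound 2 to compound 4 (0.11 log units; within the scatter), so a saturated ring and an aromatic ring cannot be told apart here, and cyclohexyl alone stands off from the other two ring groups. The large gain over ethyl now extends to an aromatic ring, with an at least 170-fold lower number from compound 1 to compound 4 (2.23 log units; beyond the scatter), and that step rests on a limit, not a number: the limit of > 10000 nM in this assay, at which 1 of the 4 values shown sits.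

The compounds shown leave open what the fluorine adds to the aromatic ring, and whether plain phenyl, 4-methoxyphenyl or a pyridine ring would hold the number at this carbon. Also open, on these data alone, is where the number falls away between ethyl and the ring groups, for instance with isopropyl or cyclopropyl, and whether an amine on this carbon would be tolerated at all.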